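Two Carbon Substituents at the Cytotoxicity Limit

The source may report more compounds than this note shows. Statements on the series, on what has been measured and on what is new or still open speak of the compounds shown alone.

Measured in a functional assay on HCT-116 cells (Homo sapiens) for cytotoxicity, with a stated time of 3 days; a lower number here means a stronger inhibitor, a higher number a weaker inhibitor:
Compound 1 `C#Cc1sc(-c2ccc(F)cc2)nc1C(=O)OCC`: > 40000 nM (a limit)
Compound 2 `C=Cc1csc(Br)n1`: > 40000 nM (a limit)
Compound 3 `Ic1nc2ccccc2s1`: > 40000 nM (a limit)

Compound 1 yields no exact number, only a limit, and the other two compounds share this position: the limit of > 40000 nM in this assay, at which 3 of the 3 values shown sit. Compound 4 `C=Cc1sc(-c2ccc(F)cc2)nc1C(=O)OCC` keeps the core of compound 1 and carries vinyl in place of ethynyl on an aromatic carbon. The change sits next to the ring sulfur and next to the ring atom that bears the ethoxycarbonyl group.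

Among the compounds with values here, no measured pair isolates this change, so the data give it no size. In this assay, a step beyond the scatter is not expected, and neither direction is favoured. This expectation rests partly on compound 1, whose > 40000 nM is a limit. Compound 2 also carries vinyl, and its > 40000 nM is likewise a limit. The expected step is a number no higher from compound 1 to compound 4 (the limit leaves the size open). Compound 4 is expected at 40000 nM, with an estimated range of 15000 nM to 80000 nM.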

Compound 4, half-maximal inhibitory concentration: > 40000 nM
Compound 4: a limit, no number; the forecaster's own chance of this, stated with the estimate: 70%; the middle value lies on the limit itself.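

In this assay no step can be read from compound 1 to compound 4, because each gives only a limit: the limit of > 40000 nM in this assay, at which 4 of the 4 values shown sit.

The compounds shown leave open whether vinyl or ethynyl on the shared core can give an exact number in this assay, and how far apart the two groups would lie.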